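Octylsulfonamido benzoic acid stilbenes: methoxy step on second core

The compounds below may be only part of what the source reports. "The series", "measured", "known", "first", "only" and "open" are said of these compounds alone.

Measured so far, in an assay on mitochondria (strain BALB/c) for inhibition of glycerol-3-phosphate acyltransferase 1, mitochondrial (Mus musculus), read by scintillation counting, with a stated time of 10 min; a lower number here means a stronger inhibitor, a higher number a weaker inhibitor:
compound 1 `CCCCCCCCS(=O)(=O)Nc1cc(/C=C/c2ccccc2)ccc1C(=O)O`, 38000 nM
compound 2 `CCCCCCCCS(=O)(=O)Nc1cc(/C=C/c2ccc(OC)cc2)ccc1C(=O)O`, 38700 nM
compound 3 `CCCCCCCCS(=O)(=O)Nc1ccc(/C=C/c2ccccc2)cc1C(=O)O`, 16300 nM

Compound 1 and compound 3 have the same atoms joined differently; the difference between the two cores is not broken down here. What the values show is that compound 3 gives the lowest of the three numbers, with compound 1 and compound 2 both beyond the scatter above it.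

The change from compound 1 to compound 2 is methoxy in place of hydrogen on an aromatic carbon, and it made a step of a 1.0-fold higher number from compound 1 to compound 2 (0.01 log units; within the scatter). Compound 4 `CCCCCCCCS(=O)(=O)Nc1ccc(/C=C/c2ccc(OC)cc2)cc1C(=O)O` carries the same change on the core of compound 3: methoxy in place of hydrogen on an aromatic carbon. The place of the change is the same in both pairs, so this is the same change, made once on each core.

Because the step of a 1.0-fold higher number from compound 1 to compound 2 (0.01 log units; within the scatter) lay within the scatter, the step from compound 3 to compound 4 in this assay is expected to be a 1.0-fold higher number from compound 3 to compound 4 (0.02 log units; within the scatter), that is, essentially flat. Compound 4 is estimated at 17000 nM, with a likely range from 8000 nM to 34000 nM.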

Compound 4, half-maximal inhibitory concentration: 37100 nM
Beside the measured number, compound 4's estimate is 2.2-fold (0.34 log units) below it; measured number above the stated range.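

In this assay, methoxy in place of hydrogen on an aromatic carbon gives a 2.3-fold higher number from compound 3 to compound 4 (0.36 log units; beyond the scatter), against a 1.0-fold higher number from compound 1 to compound 2 (0.01 log units; within the scatter) for the same change on the other core. Set side by side, the two steps cannot be told apart: the same change on two cores in this assay, a 1.0-fold higher number (0.01 log units; within the scatter) from compound 1 to compound 2 and a 2.3-fold higher number (0.36 log units; beyond the scatter) from compound 3 to compound 4, 2.2-fold (0.35 log units) apart, within the scatter of two such steps. The result therefore does not show that the change acts differently on the two cores, nor does it show that the change carries over unchanged; a single pair on each core is too little to separate a small shared effect from scatter.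

Left open is whether another group at the same place, such as fluorine, a hydroxyl or an amine, would give steps that do separate the two cores. Also open, as far as these compounds go, is whether a longer chain in place of octyl would leave the methoxy step as it stands on either core.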